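Hydrazone aryl variation: bromine removed, fluorine retained

The source may report more compounds than this note shows. Statements on the series, on what has been measured and on what is new or still open speak of the compounds shown alone.

Working notes on the hydrazone series sharing one core. Compound 3 `Cn1c(=O)c(=O)n(C2CCCC2)c2nc(N/N=C/c3ccc(F)cc3Br)ncc21` gives 9250 nM in a functional assay on PC-3 cells (Homo sapiens) for antiproliferative activity, read by MTT assay (on this read-out higher numbers stand for weaker inhibition and lower numbers for stronger inhibition), the lowest of the two numbers in hand. Compound 1 `COc1cccc(/C=N/Nc2ncc3c(n2)n(C2CCCC2)c(=O)c(=O)n3C)c1` gives 20700 nM in this assay. Compound 2 `COc1ccc(/C=N/Nc2ncc3c(n2)n(C2CCCC2)c(=O)c(=O)n3C)c(OC)c1` reaches only the limit > 100000 nM, a limit of the assay rather than a number. Compound 3 sits a 2.2-fold lower number from compound 1 to compound 3 (0.35 log units; beyond the scatter) and an at least 10-fold lower number from compound 2 to compound 3 (1.03 log units; beyond the scatter).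

Compound 4 `Cn1c(=O)c(=O)n(C2CCCC2)c2nc(N/N=C/c3ccccc3F)ncc21` is not yet measured. The change is 2-fluorophenyl in place of 2-bromo-4-fluorophenyl on a carbon with a double bond to nitrogen. Going by the values given here, no measured step removes a bromine from the aryl group; the two steps in hand, a 2.2-fold lower number from compound 1 to compound 3 (0.35 log units; beyond the scatter) and an at least 10-fold lower number from compound 2 to compound 3 (1.03 log units; beyond the scatter), only show that a halogenated aryl gives lower numbers than methoxy-bearing aryls, and they do not separate the contributions of the two halogens. A step within or near the scatter is therefore expected, tending slightly toward a higher number as the aryl loses a substituent.

Compound 4 is estimated at 14000 nM in this assay, between 5000 nM and 40000 nM. The expected step from compound 3 to compound 4 is a 1.5-fold higher number from compound 3 to compound 4 (0.18 log units; within the scatter).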

Compound 4, half-maximal inhibitory concentration: 27600 nM
Compound 4: the middle estimate sits 2.0-fold (0.29 log units) below what was measured; the measured number falls inside the stated range.
By their numbers in this assay, from the lowest: compound 3; then compounds 1 and 4 (each within the scatter of the next). At a limit, above all of these: compound 2.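

Going to 2-fluorophenyl gives a 3.0-fold higher number from compound 3 to compound 4 (0.47 log units; beyond the scatter), so the two halogen-bearing aryl groups on the carbon with a double bond to nitrogen do not behave alike. A halogen on the aryl group is therefore not enough to give a lower number than a methoxy-bearing aryl group: compound 4 goes against that reading with a 1.3-fold higher number from compound 1 to compound 4 (0.12 log units; within the scatter), although an at least 3.6-fold lower number from compound 2 to compound 4 (0.55 log units; beyond the scatter) still stands. That last step is only a bound, since compound 2 is a limit and not a number: the limit of > 100000 nM in this assay, at which 1 of the 4 values shown sits.

This one change alters both the bromine and the fluorine of compound 3, so the compounds shown do not separate the two halogens. Also open, going by these compounds, is how an aryl group with bromine as its only halogen, or one carrying an amine or a nitrile, would compare.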